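The compounds below may be only part of what the source reports. "The series", "measured", "known", "first", "only" and "open" are said of these compounds alone.

Compound 1: `Cc1ccc(-c2nn(-c3ccc(Cl)cc3Cl)cc2C(=O)Nc2ccc(C)c(S(=O)(=O)N3CCOCC3)c2)cc1` — 1240 nM
Compound 2: `Cc1ccc(-c2nn(Cc3ccc4ccccc4c3)cc2C(=O)Nc2ccc(C)c(S(=O)(=O)N3CCOCC3)c2)cc1` — 844 nM

Within the data shown here, in an assay on HEK-293T cells for inhibition of Bile acid receptor (Homo sapiens), read by a beta-lactamase reporter, with a stated time of 16 h (a higher number here means a weaker inhibitor, a lower number a stronger inhibitor), compound 2 gives 844 nM, the lowest of the two numbers so far; the only neighbour is compound 1, and the gap between them, a 1.5-fold lower number from compound 1 to compound 2 (0.17 log units; within the scatter), is within the scatter. Compound 3 `Cc1ccc(-c2nn(CC3CC3)cc2C(=O)Nc2ccc(C)c(S(=O)(=O)N3CCOCC3)c2)cc1` has not been measured yet. It differs from compound 2 in one place: cyclopropyl in place of naphthalen-2-yl on a saturated chain carbon bound to an aromatic nitrogen. Among the measured compounds shown here, the one measured step that touches this part of the molecule exchanged one group on the aromatic nitrogen for another without moving the number beyond the scatter, but it kept an aromatic ring system in place, whereas here two aromatic rings give way to a small three-membered ring. With nothing directly comparable to lean on, a modest loss is expected rather than a gain. Compound 3 is therefore estimated at about 2000 nM, in a range from 700 nM to 6000 nM. The expected step from compound 2 to compound 3 is a 2.4-fold higher number from compound 2 to compound 3 (0.37 log units; beyond the scatter).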

Compound 3, half-maximal inhibitory concentration: 849 nM
Beside the measured number, compound 3's estimate is 2.4-fold (0.37 log units) above it; the measured number falls inside the stated range.
By their numbers in this assay, from the lowest: compounds 2, 3 and 1 (each within the scatter of the next).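

In this assay, cyclopropyl in place of naphthalen-2-yl on a saturated chain carbon bound to an aromatic nitrogen gives a 1.0-fold higher number from compound 2 to compound 3 (0.00 log units; within the scatter), so exchanging two six-membered aromatic rings for one three-membered non-aromatic ring, with far fewer heavy atoms, leaves the number within the scatter. Cyclopropylmethyl in place of 2,4-dichlorophenyl on the aromatic nitrogen also stays within the scatter, at a 1.5-fold lower number from compound 1 to compound 3 (0.16 log units; within the scatter), so among these three compounds, an aromatic ring in this group is not needed for a number of this size in this assay. No measurement here explains this tolerance.

On these data alone, all three compounds lie within the scatter of one another, so it remains open whether any change at this position can shift the number beyond it. A carboxylic acid, an amine or a longer chain at this position would test that.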